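The source may hold more compounds than are shown below. What is called first, only, known or untested is meant among the compounds shown, and "the series" means these compounds.

Measured compounds in a functional assay on HCT-15 cells (Homo sapiens) for cytotoxicity, read by CCK-8 assay and cell counting, with a stated time of 2 days; a lower number here means a stronger inhibitor, a higher number a weaker inhibitor:
compound 1 `Oc1cccc(-c2cc(-c3ccc(Cl)cc3)nc(-c3cccs3)c2)c1`: 9280 nM
compound 2 `Oc1ccc(-c2cc(-c3cccs3)nc(-c3ccccc3Cl)c2)cc1`: 5430 nM
compound 3 `Oc1ccc(-c2cc(-c3ccc(Cl)cc3)nc(-c3ccccn3)c2)cc1`: 21300 nM

Compound 3 gives the highest number of the three, and so is the weakest inhibitor in this assay; compound 1 is nearest to it and compound 2 furthest, and both gaps lie beyond the scatter. Compound 4 `Oc1ccc(-c2cc(-c3ccc(Cl)cc3)nc(-c3cccs3)c2)cc1` has not yet been measured. It differs from compound 3 in one place: thiophen-2-yl in place of pyridin-2-yl on an aromatic carbon. Compounds 1 and 2, which both carry a thiophen-2-yl group, give the two lower numbers, so a step toward stronger inhibition is expected, as a 2.8-fold lower number from compound 3 to compound 4 (0.45 log units; beyond the scatter). Compound 4 is thus estimated at 7500 nM, with a range from 3000 nM to 18000 nM.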

Compound 4, half-maximal inhibitory concentration: 6470 nM
Beside the measured number, compound 4's estimate is 1.2-fold (0.06 log units) above it; the measured number falls inside the stated range.
By their numbers in this assay, from the lowest: compounds 2, 4 and 1 (each within the scatter of the next); then compound 3.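

In this assay, within the data shown here, thiophen-2-yl in place of pyridin-2-yl next to the ring nitrogen gives a 3.3-fold lower number from compound 3 to compound 4 (0.52 log units; beyond the scatter) and is the first one-place reading at this position. With thiophen-2-yl present, 4-chlorophenyl in place of 2-chlorophenyl gives a 1.2-fold higher number from compound 2 to compound 4 (0.08 log units; within the scatter) and 4-hydroxyphenyl in place of 3-hydroxyphenyl gives a 1.4-fold lower number from compound 1 to compound 4 (0.16 log units; within the scatter) and both steps lie within the scatter. No measurement at hand accounts for these steps.

The compounds shown leave open whether a furan-2-yl or plain phenyl group at this position would match thiophen-2-yl. They also leave open whether the step would hold with a methoxy group in place of the hydroxyl.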